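The compounds below may be only part of what the source reports. "The series", "measured", "known", "first", "only" and "open" are said of these compounds alone.

- compound 1 `N=C(N)N/N=C/c1c(-c2ccccn2)nc2sc(Cl)cn12`: 7760 nM
- compound 2 `N=C(N)N/N=C/c1c(-c2cccnc2)nc2sc(Cl)cn12`: 18200 nM
- compound 3 `N=C(N)N/N=C/c1c(-c2ccncc2)nc2sc(Cl)cn12`: not yet measured

In a functional assay (Homo sapiens) for antiproliferative activity (on this read-out lower numbers stand for stronger inhibition of growth and higher numbers for weaker inhibition of growth), compound 2 gives 18200 nM, the higher of the two numbers and so the weaker growth inhibition, while compound 1 gives 7760 nM. Compound 3 keeps the core of compound 2 and changes only the attached ring: pyridin-4-yl in place of pyridin-3-yl on an aromatic carbon. Among the measured compounds shown here, one measured step bears on this, also a swap between pyridine attachment points: a 2.3-fold higher number from compound 1 to compound 2 (0.37 log units; beyond the scatter). That step is modest, and a single step shows no trend, so only a small change is expected here, with no firm direction. The estimated change is a 1.3-fold lower number from compound 2 to compound 3 (0.11 log units; within the scatter), which would stay within the usual scatter. For compound 3 the expected value is 14000 nM, with an estimated range from 5000 nM to 35000 nM.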

Compound 3, concentration for 50% growth inhibition: 5890 nM
Compound 3: the middle estimate sits 2.4-fold (0.38 log units) above what was measured; low and high end bracket the measured number.
By their numbers in this assay, from the lowest: compounds 3 and 1 (each within the scatter of the next); then compound 2.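

Pyridin-4-yl in place of pyridin-3-yl on this aromatic carbon gives a 3.1-fold lower number from compound 2 to compound 3 (0.49 log units; beyond the scatter) in this assay, the opposite direction to a 2.3-fold higher number from compound 1 to compound 2 (0.37 log units; beyond the scatter), so the number does not move steadily as the attachment point of the pyridine changes. Pyridin-4-yl in place of pyridin-2-yl gives a 1.3-fold lower number from compound 1 to compound 3 (0.12 log units; within the scatter), which leaves these two groups indistinguishable and makes compound 2, with pyridin-3-yl, the only one of the three that stands apart, even though all three groups have the same atom counts. No measurement here explains why the attachment point matters.

Still open, from the compounds shown here alone, is whether a plain phenyl ring, with no ring nitrogen, or a morpholine at this position would match compound 3 or compound 2. These three compounds also cannot show whether the same pattern would hold with another group in place of the chlorine on the shared core.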